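Swapping the Hydroxycarbamoyl Arm for a 5-Carboxypentyl Chain

The source may hold more compounds than are shown below. What is called first, only, known or untested is meant among the compounds shown, and "the series" means these compounds.

Compound 1 (`O=C(NO)c1ccc(NCCOc2ccc3cc2COC/C=C/COCc2cccc(c2)-c2ccnc(n2)N3)cc1`) reads 4580 nM in a functional assay on PC-3 cells (Homo sapiens) for antiproliferative activity, read by MTT assay, with a stated time of 72 h; a higher number here means a weaker inhibitor, a lower number a stronger inhibitor. That lies within the scatter of compound 3 (`O=C(CCCCCOc1ccc2cc1COC/C=C/COCc1cccc(c1)-c1ccnc(n1)N2)NO`) at 8110 nM and clearly apart from compound 2 (`O=C(NO)c1ccc(OCCOc2ccc3cc2COC/C=C/COCc2cccc(c2)-c2ccnc(n2)N3)cc1`) at 1600 nM, the lowest number of the three.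

Compound 4 (`O=C(O)CCCCCCCOc1ccc2cc1COC/C=C/COCc1cccc(c1)-c1ccnc(n1)N2`) differs from compound 1 on a saturated chain carbon, two bonds along the chain from an oxygen on an aromatic ring: 5-carboxypentyl in place of (4-(hydroxycarbamoyl)phenyl)amino on a saturated chain carbon, two bonds along the chain from an oxygen on an aromatic ring. The nearest measured precedent also gives up the aromatic ring for an open chain, and it shows a 1.8-fold higher number from compound 1 to compound 3 (0.25 log units; within the scatter). A second step, a 5.1-fold higher number from compound 2 to compound 3 (0.70 log units; beyond the scatter), is modest and points the same way. Going by these compounds, all three measured compounds keep a hydroxycarbamoyl group, however, so no measurement covers its loss, and the carboxy end remains untested. A modest rise is therefore expected, with the estimated change being a 3.3-fold higher number from compound 1 to compound 4 (0.52 log units; beyond the scatter) at the middle of the range. Compound 4 is expected at an estimated 15000 nM in this assay (range 6000 nM to 50000 nM) and may reach only a limit of the assay.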

Compound 4, half-maximal inhibitory concentration: 22800 nM
Estimate against measurement, compound 4: 1.5-fold (0.18 log units) below, and the stated range covers the measured number.
By their numbers in this assay, from the lowest: compound 2; then compounds 1 and 3 (each within the scatter of the next); then compound 4.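

Compound 4 is the first compound shown without a hydroxycarbamoyl group, and in this assay its carboxy-ended chain gives a 2.8-fold higher number from compound 3 to compound 4 (0.45 log units; beyond the scatter), with 2-carboxyethyl in place of hydroxycarbamoyl. Among these compounds, the aromatic arms make the gap wider, at a 5.0-fold higher number from compound 1 to compound 4 (0.70 log units; beyond the scatter) and, the only large step here, a 14-fold higher number from compound 2 to compound 4 (1.15 log units; beyond the scatter), so compound 4 now has the highest number of the four, while the step from compound 3 shows that the open chain alone does not account for all of this rise. No measurement offered here explains the rise.

That step from compound 3 both lengthens the chain and replaces the hydroxycarbamoyl end, so the two changes cannot be separated. A longer chain ending in hydroxycarbamoyl, a shorter chain ending in a carboxylic acid, or a carboxylic acid in place of hydroxycarbamoyl on the aromatic arm of compound 2 would each bear on this.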